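A few compounds are considered here, and "the series" means these few. Any claim that something is new, unique, unknown or untested is made for them only; others in the source may bear on it.

Measured so far:
compound 1, `CC1=CC[C@H](C(C)(C)NC(=S)N/N=C/c2ccccc2O)CC1`, with 10800 nM
compound 2, `CC1=CC[C@H](C(C)(C)NC(=S)N/N=C/c2cccc(Cl)c2)CC1`, with 39800 nM

Both numbers come from a functional assay on UACC-62 cells (Homo sapiens) for inhibition, read by sulforhodamine B assay, with a stated time of 48 h; a higher number here means a weaker inhibitor of growth, a lower number a stronger inhibitor of growth. Compound 1 holds the lowest of the two values, so it is the stronger growth inhibitor of the pair; the nearest neighbour is compound 2, and the step of a 3.7-fold higher number from compound 1 to compound 2 (0.57 log units; beyond the scatter) is beyond the scatter, a modest loss for 3-chlorophenyl in place of 2-hydroxyphenyl on the carbon double-bonded to nitrogen.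

The next compound, compound 3, `CC1=CC[C@H](C(C)(C)NC(=S)N/N=C/c2ccccc2[N+](=O)[O-])CC1`, keeps the shared core of compound 1 and changes only the ring substituent: nitro in place of hydroxy on an aromatic carbon. The hydroxy leaves, so one hydrogen-bond donor is lost, and the nitro that enters brings two hydrogen-bond acceptors; it sits on an aromatic carbon ortho to a large group.

For the measured compounds named here, only one measured step bears on this change, and only loosely: from compound 1 to compound 2 the hydroxy was also removed, though there a chlorine arrived at a different position, and the number rose modestly. Going by the values given here, no measured pair isolates the nitro group itself. On that basis a modest rise in this assay is expected, a 2.3-fold higher number from compound 1 to compound 3 (0.36 log units; beyond the scatter), with wide uncertainty. Compound 3 is therefore estimated at 25000 nM, with a range from 8000 nM to 80000 nM.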

Compound 3, concentration for total growth inhibition: 92200 nM
Beside the measured number, compound 3's estimate is 3.7-fold (0.57 log units) below it; the measured number lies above the stated range.
By their numbers in this assay, from the lowest: compound 1; then compound 2; then compound 3.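

In this assay, changing only the group on the aromatic carbon ortho to a large group gives an 8.5-fold higher number from compound 1 to compound 3 (0.93 log units; beyond the scatter), so this carbon is sensitive to what it carries, and the change here is beyond the scatter. The earlier step, a 3.7-fold higher number from compound 1 to compound 2 (0.57 log units; beyond the scatter), changed both the group and its place on the ring, whereas this step keeps the place and changes only the group, which gives a cleaner reading of this position. Nothing measured on these compounds accounts for the size of this loss.

The compounds shown leave open whether the rise in the number follows from the hydroxy leaving, with its hydrogen-bond donor, or from the nitro entering, and a plain hydrogen, a methoxy group or an amine on the same aromatic carbon would help to tell these apart. Also open, going by these compounds, is how a chlorine would compare with the hydroxy and the nitro on this same carbon, since the only chlorine shown sits elsewhere on the ring, in the 3-chlorophenyl of compound 2.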